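The compounds below may be only part of what the source reports. "The series", "measured", "known", "first", "only" and "open" are said of these compounds alone.

Measured in a functional assay on A549 cells (Homo sapiens) for antiproliferative activity, read by MTT assay, with a stated time of 48 h; on this read-out lower numbers stand for stronger inhibition and higher numbers for weaker inhibition:
- Compound 1 `Cn1cc(C2=C(c3nn(CCn4ccnc4)c4ncccc34)C(=O)N(c3ccccc3)C2=O)c2ccccc21`: 43100 nM
- Compound 2 `CN(C)CCCn1nc(C2=C(c3cn(C)c4ccccc34)C(=O)N(c3ccccc3)C2=O)c2cccnc21`: 13000 nM
- Compound 3 `Cn1cc(C2=C(c3nn(CCCCn4ccnc4)c4ncccc34)C(=O)NC2=O)c2ccccc21`: 2380 nM

Compound 3 has the lowest number of the three. Compound 4 `Cn1cc(C2=C(c3nn(CCCCn4ccnc4)c4ncccc34)C(=O)N(c3ccccc3)C2=O)c2ccccc21` differs from it by phenyl in place of hydrogen on an amide-type nitrogen in a ring, which is phenyl in place of hydrogen on an amide-type nitrogen in a ring. Among the measured compounds shown here, no measured step isolates this change. For the measured compounds named here, the only step, a 3.3-fold lower number from compound 1 to compound 2 (0.52 log units; beyond the scatter), alters the chain end instead, so it offers little guidance. Still, the two compounds that carry the phenyl sit higher, with compound 2 at 13000 nM and compound 1 at 43100 nM, although their chains also differ from that of compound 3. A clear rise in this assay, towards weaker inhibition, is therefore expected. The expected change is a 6.7-fold higher number from compound 3 to compound 4 (0.83 log units; beyond the scatter). For compound 4 the estimated value is 16000 nM, with an expected range of 5000 nM to 45000 nM.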

Compound 4, half-maximal inhibitory concentration: 21700 nM
Estimate against measurement, compound 4: 1.4-fold (0.13 log units) below; the measured number falls inside the stated range.
By their numbers in this assay, from the lowest: compound 3; then compounds 2, 4 and 1 (each within the scatter of the next, the first and the last beyond it).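

Phenyl in place of hydrogen on the amide-type nitrogen gives a 9.1-fold higher number from compound 3 to compound 4 (0.96 log units; beyond the scatter) in this assay and thus isolates this change, which moves towards weaker inhibition. With the phenyl kept, the steps of a 1.7-fold higher number from compound 2 to compound 4 (0.22 log units; within the scatter) and a 2.0-fold lower number from compound 1 to compound 4 (0.30 log units; within the scatter) both lie within the scatter, so these chain changes show no clear effect. No measured evidence accounts for the rise caused by the phenyl.

On these data alone, whether methyl or benzyl on that nitrogen would stay close to the amide hydrogen or to phenyl remains open. So does the effect of a dimethylamino chain end when the amide hydrogen is present.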